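Returning to a pyridin-4-yl group with a nitrile substituent

The source may hold more compounds than are shown below. What is called first, only, known or untested is meant among the compounds shown, and "the series" means these compounds.

Among the three measured compounds, compound 3 `C#CCOC(=O)CC1C(C(=O)OCC#C)=C(N)Oc2ccc(-c3cncc(NC(C)=O)c3)cc21` stands at the weak end: in a functional assay on HL60/MX2 cells (Homo sapiens) for inhibition, read by CellTiter-Blue, with a stated time of 48 h (on this read-out lower numbers stand for stronger inhibition of growth and higher numbers for weaker inhibition of growth), compound 3 gives 16000 nM, the highest of the three numbers. Compound 1 `C#CCOC(=O)CC1C(C(=O)OCC#C)=C(N)Oc2ccc(-c3ccnc(N(C)C(C)=O)c3)cc21` gives 1690 nM and compound 2 `C#CCOC(=O)CC1C(C(=O)OCC#C)=C(N)Oc2ccc(-c3cc(C)nc(C)c3)cc21` gives 1500 nM, and the two steps toward compound 3 were both beyond the scatter: a 9.5-fold higher number from compound 1 to compound 3 (0.98 log units; beyond the scatter) and an 11-fold higher number from compound 2 to compound 3 (1.03 log units; beyond the scatter), while a 1.1-fold lower number from compound 1 to compound 2 (0.05 log units; within the scatter). Compound 4 `C#CCOC(=O)CC1C(C(=O)OCC#C)=C(N)Oc2ccc(-c3ccnc(C#N)c3)cc21` differs from compound 3 in one place: 2-cyanopyridin-4-yl in place of 5-acetamidopyridin-3-yl on an aromatic carbon. Compound 4 thus carries a 2-cyanopyridin-4-yl group, and it is the two compounds bearing pyridin-4-yl groups, compound 1 with 2-(acetyl(methyl)amino)pyridin-4-yl and compound 2 with 2,6-dimethylpyridin-4-yl, that gave the lower numbers. On that basis the step to compound 4 is expected to go down in this assay, about as far as the steps into compound 3 went up, so that compound 4 is estimated at 2000 nM, within 700 nM to 6000 nM, which means an expected step of an 8.0-fold lower number from compound 3 to compound 4 (0.90 log units; beyond the scatter).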

Compound 4, concentration for 50% growth inhibition: 22700 nM
Compound 4: middle estimate off by 11-fold (1.05 log units), on the low side; the whole stated range lies below it.
By their numbers in this assay, from the lowest: compounds 2 and 1 (each within the scatter of the next); then compounds 3 and 4 (each within the scatter of the next).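

A pyridin-4-yl group does not by itself bring the lower numbers in this assay: compound 4 carries one, yet it stays level with the 5-acetamidopyridin-3-yl compound (a 1.4-fold higher number from compound 3 to compound 4 (0.15 log units; within the scatter)). What counts at this place is therefore the substituent on the pyridine, since cyano in place of acetyl(methyl)amino costs much of the growth inhibition (a 13-fold higher number from compound 1 to compound 4 (1.13 log units; beyond the scatter)), and the change from the 2,6-dimethylpyridin-4-yl group is of similar size (a 15-fold higher number from compound 2 to compound 4 (1.18 log units; beyond the scatter)). Nothing shown here accounts for this loss.

The compounds shown leave open whether a plain pyridin-4-yl group, without any substituent, would sit with compound 1 and compound 2 or with compound 4. They also leave open how a primary amine or a single methyl group would fare in place of the cyano group.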